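The compounds below may be only part of what the source reports. "The series", "measured", "known", "first", "only" and "open" are said of these compounds alone.

Measured in a functional assay on the whole organism (strain Hartley) for inhibition, with Cavia porcellus as the target, with stated times of 15 min and 2 min; a lower number here means that less compound is needed, a higher number that more compound is needed for the effect:

- compound 1 `CCCCC1([C@@H](O)/C=C/C2[C@H](O)CC(=O)[C@@H]2CCCCCCC(=O)O)CCC1`: 0.017 mg/kg
- compound 2 `CCCCC1([C@H](O)/C=C/C2CCC(=O)[C@@H]2CCCCSCC(=O)OCC)CCC1`: 0.03 mg/kg
- compound 3 `CCCCC1([C@@H](O)/C=C/C2CCC(=O)[C@@H]2CCCCSCC(=O)OCC)CCC1`: > 0.672 mg/kg (a limit)

Compound 2, at 0.03 mg/kg, stands with compound 1, at 0.017 mg/kg, and these two numbers lie within the scatter of each other. Among the compounds with values here, they are the only two numbers, since the entry for compound 3 is a limit.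

Compound 4 `CCCCC1([C@H](O)/C=C/C2CCC(=O)[C@@H]2CCCCSCC(=O)O)CCC1` has not yet been measured. It differs from compound 2 by hydrogen in place of ethyl on an oxygen next to a carbonyl group, which reads as ethoxycarbonyl to carboxy.

Within the data shown here, no measured step covers this change. The only one, an at least 22-fold higher number from compound 2 to compound 3 (1.35 log units; beyond the scatter), is large, but it concerns (the fact that one of compounds 2 and 3 is drawn with a defined configuration and the other without, at the place where they differ), and compound 4 keeps the configuration drawn in compound 2 at that place. That step therefore warns against altering the stereocentre and says nothing about the ester. The nearest indication is compound 1, which also carries a carboxy group and gives 0.017 mg/kg, although it differs from compound 4 elsewhere as well.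

In this assay, no change beyond the scatter is therefore expected, and the estimated step is a 1.2-fold lower number from compound 2 to compound 4 (0.08 log units; within the scatter). The expected value for compound 4 is 0.025 mg/kg, with an estimated range from 0.007 mg/kg to 0.09 mg/kg.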

Compound 4, dose for half-maximal effect: 0.0912 mg/kg
Beside the measured number, compound 4's estimate is 3.6-fold (0.56 log units) below it, outside the stated range (above it).
By their numbers in this assay, from the lowest: compounds 1 and 2 (each within the scatter of the next); then compound 4. At a limit, above all of these: compound 3.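

In this assay, the change from ethoxycarbonyl to carboxy gives a 3.0-fold higher number from compound 2 to compound 4 (0.48 log units; beyond the scatter) and so counts as a real, if modest, change. Within the data shown here, the only step measured earlier concerned a stereocentre, so this is the first sign that the group at the end of the thioether chain also affects the dose needed, with the ethyl group on this oxygen giving the lower number in this one pair. Nothing shown here gives a reason for this step.

The compounds shown leave open whether another group at this place, such as methoxycarbonyl, a primary amide or an ester with a longer chain on the oxygen, would stay with compound 2 or move towards compound 4. As far as these compounds go, it also remains open how the carboxy group would read with the configuration drawn in compound 3, whose > 0.672 mg/kg is a limit and not a number.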